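The compounds below may be only part of what the source reports. "The series", "measured", "known", "first", "only" and "open" are said of these compounds alone.

Measured so far:
compound 1, `O=[N+]([O-])c1ccc(O[C@H]2CCc3ccccc3[C@@H]2n2ccnc2)c(F)c1`, 32.1 ug/mL
compound 2, `O=[N+]([O-])c1ccc(O[C@H]2CCc3ccccc3[C@@H]2n2ccnn2)cc1`, > 100 ug/mL

In an ADME assay on J774.A1 cells (Mus musculus) for cytotoxicity, read by MTT assay (a higher number here means that more compound is tolerated, a lower number that less compound is tolerated), compound 1 gives 32.1 ug/mL. For compound 2 the read-out is a limit of the assay: in this assay compound 2 gives > 100 ug/mL. Compound 2 thus stands at the limit of > 100 ug/mL in this assay, at which 1 of the 2 values shown sits, and its position relative to compound 1 is known only as a limit, not as a number. Among the compounds with values here, compounds 1 and 2 differ in two places, so no single step connects them.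

Compound 3, `O=[N+]([O-])c1ccc(O[C@H]2CCc3ccccc3[C@@H]2n2ccnn2)c(F)c1`, is not yet measured. It differs from compound 2 by fluoro in place of hydrogen on an aromatic carbon. Within the data shown here, compound 1 carries the same fluoro and returns a number rather than a limit, but it also differs from compound 2 in another part of the molecule, so no measured step isolates the fluoro. The expected step in this assay an at least 1.6-fold lower number from compound 2 to compound 3 (0.22 log units; that floor lies within the scatter) is a modest loss of tolerance beyond the scatter, with a fair chance that compound 3 again sits at the limit. Compound 3 is estimated at 60 ug/mL (range 25 ug/mL to 120 ug/mL).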

Compound 3, half-maximal cytotoxic concentration: > 100 ug/mL
Compound 3 was reported as a limit; the forecaster's own chance of this, stated with the estimate: 40%; middle value at least 1.6-fold (0.22 log units) away from the limit.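

In this assay compound 3 gives > 100 ug/mL, which is a limit of the assay and not a number. With the fluoro common to both, 1H-1,2,3-triazol-1-yl in place of 1H-imidazol-1-yl on the saturated ring carbon gives an at least 3.1-fold higher number from compound 1 to compound 3 (0.49 log units; beyond the scatter), so the fluoro on its own does not bring the series down to the number seen for compound 1, and the difference between these two compounds lies with the ring on the saturated carbon. The step for fluoro in place of hydrogen cannot be read, since both of its compounds sit at the same limit: the limit of > 100 ug/mL in this assay, at which 2 of the 3 values shown sit.

Within the data shown here, still open is whether fluoro in place of hydrogen changes anything when 1H-imidazol-1-yl is present, since no pair isolates it there. Also open, on these data alone, is how the read-out responds to an amine on the saturated ring carbon, or to a nitrile in place of the nitro group.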